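The source may report more compounds than this note shows. Statements on the series, on what has been measured and on what is new or still open speak of the compounds shown alone.

Measured compounds and their values:
Compound 1, `OC[C@H]1O[C@@H](n2cnc3c(NCc4ccccc4Cl)ncnc32)[C@H](O)[C@@H]1O`, in a functional assay on HOS cells (Homo sapiens) for antiproliferative activity, with a stated time of 72 h (a lower number here means a stronger inhibitor, a higher number a weaker inhibitor), gives > 166000 nM, which is a limit of the assay rather than a number.
Compound 2, `OC[C@H]1O[C@@H](n2cnc3c(NCc4ccc(Cl)cc4)ncnc32)[C@H](O)[C@@H]1O`, in this assay gives > 166000 nM, again a limit and not a number.
Compound 3, `OC[C@H]1O[C@@H](n2cnc3c(NCc4ccc(F)cc4F)ncnc32)[C@H](O)[C@@H]1O`, in this assay gives > 166000 nM, also only a limit.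

All three compounds share the same core and differ only in the aromatic group attached to a saturated chain carbon bound to a nitrogen on an aromatic ring. Compound 3 therefore stands at the same place as the other two: at the limit, as the limit of > 166000 nM in this assay, at which 3 of the 3 values shown sit, shows. The steps among them, a step that the two limits leave unreadable from compound 1 to compound 2, a step that the two limits leave unreadable from compound 1 to compound 3 and a step that the two limits leave unreadable from compound 2 to compound 3, cannot be sized, since each compound sits at the limit.

Compound 4, `COc1cccc(CNc2ncnc3c2ncn3[C@@H]2O[C@H](CO)[C@@H](O)[C@H]2O)c1O`, is the next compound to be measured. It differs from compound 3 by the change (2-hydroxy-3-methoxyphenyl in place of 2,4-difluorophenyl on a saturated chain carbon bound to a nitrogen on an aromatic ring). The measured steps bear on this change only in showing that exchanging one aromatic group for another has not moved any compound off the limit, so no step beyond the scatter is expected in this assay, in either direction. Compound 4 is expected to give about 250000 nM, with a range from 40000 nM to 1500000 nM, and the step that the limit leaves unreadable from compound 3 to compound 4 is expected to be small.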

Compound 4, half-maximal inhibitory concentration: > 166000 nM
Compound 4 gave a limit, no number; the forecaster's own chance of this, stated with the estimate: 80%; the middle value does not contradict the limit.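

Compound 4 in this assay gives > 166000 nM, which is a limit and not a number, so no step from compound 1, compound 2 or compound 3 to compound 4 can be read, since all of them sit at the same ceiling: the limit of > 166000 nM in this assay, at which 4 of the 4 values shown sit.

The compounds shown leave open whether any aromatic group on this shared core gives a measurable antiproliferative effect.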